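A Fluorine Added to the Phenyl Ring of Compound 1

A few compounds are considered here, and "the series" means these few. Any claim that something is new, unique, unknown or untested is made for them only; others in the source may bear on it.

Measured compounds:
- compound 1, `CC(C)n1nc(-c2cc(-c3ccccc3)on2)c2c(N)ncnc21`: 190 nM
- compound 2, `CC(C)n1nc(/C=N/O)c2c(N)ncnc21`: 4900 nM

Both compounds were tested in an assay on isolated protein for inhibition of proto-oncogene tyrosine-protein kinase receptor Ret (Homo sapiens), read by radiometric assay and 33P incorporation, in the presence of a further agent that is not named here; a lower number here means a stronger inhibitor, a higher number a weaker inhibitor. Compound 1 gives 190 nM, the lowest of the two numbers and so the stronger inhibitor of the pair. Compound 2 gives 4900 nM, a gap that lies beyond the usual scatter of this kind of measurement, so compound 1 stands clearly ahead on the numbers shown.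

Compound 3, `CC(C)n1nc(-c2cc(-c3ccc(F)cc3)on2)c2c(N)ncnc21`, has not yet been measured. It differs from compound 1 in a single place: fluoro in place of hydrogen on an aromatic carbon. Cut one bond further out, the change reads phenyl to 4-fluorophenyl, with the shared core left untouched.

For the measured compounds named here, no two measured compounds differ in only this way, so there is no measured step to lean on. A change of one heavy atom on the outer ring is expected to move the number little, in either direction, most likely within the scatter; the step of a 1.2-fold lower number from compound 1 to compound 3 (0.07 log units; within the scatter) is therefore estimated to be small. Compound 3 is expected to give about 160 nM, somewhere between 60 nM and 450 nM.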

Compound 3, half-maximal inhibitory concentration: 150 nM
The estimate for compound 3 lay 1.1-fold (0.03 log units) above the measured number, and the stated range covers the measured number.
By their numbers in this assay, from the lowest: compounds 3 and 1 (each within the scatter of the next); then compound 2.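

For the compounds shown here, compound 3 gives the first measured step on the outer ring: in this assay, fluoro in place of hydrogen gives a 1.3-fold lower number from compound 1 to compound 3 (0.10 log units; within the scatter), so the two compounds cannot be told apart. Going by these compounds alone, this place on the phenyl ring, para to a large group, therefore accepts one fluorine with no change in the number that can be read beyond ordinary repeat variation, something the earlier compounds could not show, as they offered no step at this position. Nothing on hand offers a reason for this result.

As far as these compounds go, a fluorine adds only a single heavy atom, so it remains open whether something bigger or charged at the same place, such as a methoxy group, an amine or a carboxylic acid, would leave the number just as steady or move it beyond the scatter. One step also cannot say whether fluoro elsewhere on the phenyl ring would behave the same way.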